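This account rests on a few compounds, and the source may have more. Where it says the series, first, only, none or still open, it means among the compounds named here.

Measured so far in an ADME assay on BJ cells (Homo sapiens) for cytotoxicity, read by CellTiter-Glo and resazurin assay, with a stated time of 72 h; a lower number here means that less compound is needed, a higher number that more compound is needed for the effect:
- compound 1 `CCOC(=O)CCCCCOc1cccc(CN(C(=O)c2ccc(-c3ccc4[nH]ccc4c3)cc2)C(C)C)c1`: > 26000 nM (a limit)
- compound 2 `CCOC(=O)CCCCCOc1cccc(CN(C(=O)c2ccc(-c3cccc(OC(F)(F)F)c3)cc2)C(C)C)c1`: > 26000 nM (a limit)

Neither entry is a true number, since each only marks where the measurement ran out. For the measured compounds named here, compound 2 therefore has no exact place on the scale, and its only reading is the limit > 26000 nM. The one other reading shown is also a limit, so the two compounds share the same ceiling: the limit of > 26000 nM in this assay, at which 2 of the 2 values shown sit.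

The next compound is compound 3 `CCOC(=O)CCCCCOc1cccc(CN(C(=O)c2ccc(-c3cccc(F)c3)cc2)C(C)C)c1`. It differs from compound 2 by a single change, fluoro in place of trifluoromethoxy on an aromatic carbon, meta to a large group.

Going by the values given here, the only measured step bearing on this change is a step that the two limits leave unreadable from compound 1 to compound 2, and it offers no size to carry forward. A swap at this same aromatic position left the reading at the limit, so no change beyond the usual scatter is expected in this assay, in either direction. The expected step is a step that the limit leaves unreadable from compound 2 to compound 3. Compound 3 is estimated at 30000 nM, with an expected range of 14000 nM to 60000 nM, and another limit is the likeliest report.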

Compound 3, half-maximal effective concentration: > 26000 nM
Compound 3 gave a limit, no number; the forecaster's own chance of this, stated with the estimate: 85%; the middle value is on the limit's open side.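

Compound 3 also gives a limit and not a true number, so no step among compound 1, compound 2 and compound 3 can be read, and all three share one ceiling: the limit of > 26000 nM in this assay, at which 3 of the 3 values shown sit.

The compounds shown leave open what concentration would reach the half-maximal effect in this assay for any of the three, and whether 1H-indol-5-yl, 3-(trifluoromethoxy)phenyl and 3-fluorophenyl differ at all.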